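The compounds below may be only part of what the source reports. "The series", "measured", "known", "first", "only" and "open" are said of these compounds alone.

Measured in an assay on isolated protein for inhibition of protein kinase C zeta type (Homo sapiens), with a stated time of 4 min, tested at 62.5 uM; on this read-out lower numbers stand for less inhibition and higher numbers for more inhibition at the one concentration tested (going by the name of the read-out):
compound 1, `CC(C)(C)C1=NN(c2ccc(F)cc2)C(c2ccc(O)cc2)C1`: 95.5%
compound 2, `CC(C)(C)C1=NN(c2ccccc2F)C(c2ccc(O)cc2)C1`: 57.6%

Compound 1 stands highest of the two numbers in this assay. Its nearest neighbour is compound 2, and the step of a number 37.9 percentage points lower from compound 1 to compound 2 (beyond the scatter) lies beyond the scatter. Within the data shown here, that single step is the only measured change at the amine nitrogen in the ring, and it shows that going from 4-fluorophenyl to 2-fluorophenyl there removes a large share of the inhibition.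

Compound 3, `CC(C)(C)C1=NN(c2c(Cl)cccc2Cl)C(c2ccc(O)cc2)C1`, has not yet been measured. Against compound 1 the change is 2,6-dichlorophenyl in place of 4-fluorophenyl on an amine nitrogen in a ring. Among the measured compounds shown here, the one step that bears on it, a number 37.9 percentage points lower from compound 1 to compound 2 (beyond the scatter), went downward for a change at the same place, so for compound 3 a step downward beyond the scatter in this assay is expected, of a size near that step or larger. The expected step is a number 45.5 percentage points lower from compound 1 to compound 3 (beyond the scatter). Whether 2,6-dichlorophenyl behaves like 2-fluorophenyl cannot be read from two measured compounds, so the range is kept wide. Compound 3 is therefore estimated at 50%, within 20% to 85%.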

Compound 3, a percentage reported as inhibition, at one concentration (the size of the read-out at that concentration, not a potency): 65.5%
Compound 3: the middle estimate sits 15.5 percentage points below what was measured, and the stated range covers the measured number.
By their numbers in this assay, from the lowest: compounds 2 and 3 (each within the scatter of the next); then compound 1.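

In this assay the 2,6-dichlorophenyl group on the amine nitrogen in the ring also gives less inhibition than 4-fluorophenyl (a number 30 percentage points lower from compound 1 to compound 3 (beyond the scatter)), so the drop is not confined to 2-fluorophenyl, and among these three compounds only the 4-fluorophenyl group of compound 1 gives the high number. The 2-fluorophenyl and 2,6-dichlorophenyl groups cannot be separated in this read-out (a number 7.9 percentage points higher from compound 2 to compound 3 (within the scatter)), so at this position the series shows no measurable difference between a single fluorine and two chlorines on the phenyl ring, even though the entering group is the larger by the heavy-atom count. No data at hand bear on the reason for these differences.

As far as these compounds go, whether the high number of compound 1 depends on the fluorine itself remains open, and plain phenyl, 4-chlorophenyl or 4-methoxyphenyl on the same nitrogen would test this. Also open, from the compounds shown here alone, is whether 3-fluorophenyl falls with the 2-fluorophenyl and 2,6-dichlorophenyl compounds or with compound 1, and single-concentration numbers of this kind give no potency for any of the three.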